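Methylsulfonyl for Cyano, Repeated on a Second Core

A few compounds are considered here, and "the series" means these few. Any claim that something is new, unique, unknown or untested is made for them only; others in the source may bear on it.

Compound 1 `CC(C)(C)OC(=O)N1CCN(C(=O)c2cn(-c3ccc(C#N)cc3F)nn2)CC1` and compound 2 `CC(C)(C)OC(=O)N1CCN(C(=O)c2cn(-c3ccc(S(C)(=O)=O)cc3F)nn2)CC1` share one core and differ by methylsulfonyl in place of cyano on an aromatic carbon. In an assay on HEK293 cells for agonist activity at Glucose-dependent insulinotropic receptor (Homo sapiens), read by a luciferase reporter, with a stated time of 24 h (on this read-out lower numbers stand for an effect already at smaller amounts and higher numbers for an effect only at larger amounts of compound), compound 1 gives 4.21 nM, while compound 2 gives 12.4 nM, a step of a 2.9-fold higher number from compound 1 to compound 2 (0.47 log units; beyond the scatter). Compound 3 `CC(C)(C)OC(=O)N1CCC(OC(=O)c2cn(-c3ccc(C#N)cc3F)nn2)CC1` is built on a different core; the difference between the two cores is not broken down here. In this assay compound 3 gives 3.59 nM, which lies within the scatter of compound 1. Compound 4 `CC(C)(C)OC(=O)N1CCC(OC(=O)c2cn(-c3ccc(S(C)(=O)=O)cc3F)nn2)CC1` carries the same change on the core of compound 3, (methylsulfonyl in place of cyano on an aromatic carbon). Since that change is the same, compound 4 is expected to move by about a 2.9-fold higher number from compound 3 to compound 4 (0.47 log units; beyond the scatter), resting on the step already seen for compound 2 a 2.9-fold higher number from compound 1 to compound 2 (0.47 log units; beyond the scatter). Compound 4 is therefore estimated at 10.5 nM, expected to fall between 4.5 nM and 25 nM.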

Compound 4, half-maximal effective concentration: 14 nM
Beside the measured number, compound 4's estimate is 1.3-fold (0.12 log units) below it; the range from low to high includes it.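

On the second core, methylsulfonyl in place of cyano on an aromatic carbon gives a 3.9-fold higher number from compound 3 to compound 4 (0.59 log units; beyond the scatter) in this assay. Set beside the earlier step, the change carries over between the two cores with no difference that can be told apart: the same change on two cores in this assay, a 2.9-fold higher number (0.47 log units; beyond the scatter) from compound 1 to compound 2 and a 3.9-fold higher number (0.59 log units; beyond the scatter) from compound 3 to compound 4, 1.3-fold (0.12 log units) apart, within the scatter of two such steps. This shows a repeatable step on these two cores in this one assay, but two pairs cannot show that it would hold on any other core, and they do not show why the number moves.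

The compounds shown leave open how other groups on this aromatic carbon, such as a carboxylic acid or an amine, would compare with cyano and methylsulfonyl. They also leave open whether the step would stay the same without the fluoro group.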